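A few compounds are considered here, and "the series" means these few. Any claim that something is new, unique, unknown or untested is made for them only; others in the source may bear on it.

Three compounds have been measured in a functional assay on CHO cells for agonist activity at Free fatty acid receptor 1 (Homo sapiens), read by calcium flux; on this read-out higher numbers stand for an effect only at larger amounts of compound and lower numbers for an effect already at smaller amounts:

Compound 1 `O=C(O)CCc1ccc(OCc2nnc(C(=O)Nc3ccccc3F)s2)cc1`: 580 nM
Compound 2 `COc1cccc(NC(=O)c2nnc(COc3ccc(CCC(=O)O)cc3)s2)c1`: 4680 nM
Compound 3 `O=C(O)CCc1ccc(OCc2nnc(C(=O)Nc3ccc(F)c(F)c3)s2)cc1`: 580 nM

Compound 3 stands level with compound 1, and together these two give the lowest numbers of the three; the step from the remaining compound is an 8.1-fold lower number from compound 2 to compound 3 (0.91 log units; beyond the scatter), which is beyond the scatter. Compound 4 `O=C(O)CCc1ccc(OCc2nnc(C(=O)Nc3cccc(Cl)c3)s2)cc1` is the next step from compound 3: 3-chlorophenyl in place of 3,4-difluorophenyl on an amide-type nitrogen.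

Within the data shown here, two measured steps bear on this change. One is no change at the digits printed from compound 1 to compound 3 (within the scatter), where one fluorine-bearing phenyl replaced another and the number stayed the same. The other is an 8.1-fold higher number from compound 1 to compound 2 (0.91 log units; beyond the scatter), where a methoxy-bearing phenyl replaced a fluorine-bearing one and the number rose markedly. The 3-chlorophenyl entering in compound 4 carries a halogen, as do the groups in compounds 1 and 3, not a methoxy as in compound 2. The expected step is therefore small, none beyond the scatter: a 1.0-fold higher number from compound 3 to compound 4 (0.01 log units; within the scatter). For compound 4 the estimate is 600 nM, within a range of 250 nM to 1500 nM.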

Compound 4, half-maximal effective concentration: 10600 nM
Estimate against measurement, compound 4: 18-fold (1.25 log units) below, outside the stated range (above it).
By their numbers in this assay, from the lowest: compounds 1 and 3 (each within the scatter of the next); then compound 2; then compound 4.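

In this assay, the place on the amide-type nitrogen does not treat all halogen-bearing phenyl groups alike: the swap to 3-chlorophenyl gives an 18-fold higher number from compound 3 to compound 4 (1.26 log units; beyond the scatter) and likewise an 18-fold higher number from compound 1 to compound 4 (1.26 log units; beyond the scatter) in the comparison with the 2-fluorophenyl group. A halogen alone therefore does not keep the number low, and the earlier split of halogen against methoxy breaks down, with compound 4 going against it: a 2.3-fold higher number from compound 2 to compound 4 (0.36 log units; beyond the scatter) shows the 3-chlorophenyl group ending up beyond even the 3-methoxyphenyl group. Nothing measured here accounts for this gap between closely related groups.

Still open, going by these compounds, is whether the chlorine itself sets this number, which a plain phenyl or a bromophenyl group at the same place could help to separate. On these data alone, how an amine on that ring would fare also remains unknown.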